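Switching the amine substituent on a chlorinated pyrimidine core

The compounds below may be only part of what the source reports. "The series", "measured", "known", "first", "only" and "open" are said of these compounds alone.

Compound 1 `Cc1ccccc1Nc1nc(Nc2ccc(N3CCCCC3)cn2)ncc1Cl`: > 100000 nM
Compound 2 `Cc1ccc(CNc2nc(Nc3ccc(N4CCN(C)CC4)cn3)ncc2Cl)cc1`: 18600 nM

In a functional assay on MDA-MB-231 cells (Homo sapiens) for inhibition, read by CCK-8 assay, with a stated time of 48 h (on this read-out higher numbers stand for weaker inhibition of growth and lower numbers for stronger inhibition of growth), compound 1 gives only a limit, > 100000 nM; this is the limit of > 100000 nM in this assay, at which 1 of the 2 values shown sits. Compound 2 gives 18600 nM, the only number shown in this assay. Compound 3 `CC(C)c1ccccc1Nc1nc(Nc2ccc(N3CCN(C)CC3)cn2)ncc1Cl` has 2-isopropylphenyl in place of 4-methylbenzyl on a nitrogen on an aromatic ring. Among the compounds with values here, no measured step covers such a change. Compound 1, which also carries a substituted phenyl on that nitrogen, sits at the limit, so the step from compound 2 to compound 3 is expected to weaken inhibition, a 2.2-fold higher number from compound 2 to compound 3 (0.33 log units; beyond the scatter). Compound 3 is therefore expected near 40000 nM, within 8000 nM to 150000 nM.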

Compound 3, concentration for 50% growth inhibition: 4090 nM
For compound 3 the middle estimate is 9.8-fold (0.99 log units) above the measured one; measured number below the stated range.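

In this assay, exchanging the 4-methylbenzyl group on the nitrogen for a 2-isopropylphenyl group gives a 4.5-fold lower number from compound 2 to compound 3 (0.66 log units; beyond the scatter). A substituted phenyl on this nitrogen can therefore go with stronger inhibition of growth, whereas compound 1, which differs from compound 3 in more than one place, gave only a limit. Nothing shown gives a cause for this step.

Going by these compounds, it remains open whether the isopropyl group or the change from benzyl to phenyl accounts for the step. A plain phenyl, a 2-methoxyphenyl or a 2-isopropylbenzyl on that nitrogen would separate these.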